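The compounds below may be only part of what the source reports. "The series", "measured", "known", "first", "only" and "open" are said of these compounds alone.

Measured so far in a functional assay on HT-29 cells (Homo sapiens) for cytotoxicity, read by MTT assay, with a stated time of 24 h; a higher number here means a weaker inhibitor, a lower number a stronger inhibitor:
compound 1 `COc1cc(/C=C2\SC(=O)N(Cc3ccc(C(=O)O)cc3)C2=O)cc(OC)c1OC` gives 32000 nM
compound 2 `O=C(O)c1ccc(CN2C(=O)S/C(=C\c3ccccn3)C2=O)cc1` gives 78000 nM
compound 3 `Cc1ccc(/C=C2\SC(=O)N(Cc3ccc(C(=O)O)cc3)C2=O)cc1` gives 72000 nM

Compound 2 stands at the highest of the three numbers. Its nearest neighbour is compound 3, and the values of compound 2 and compound 3 lie within the scatter of each other, so no order between them can be read. Compound 1 shows the lowest of the three values; the gap between compound 2 and compound 1 lies beyond the scatter, so of that pair compound 1 is the stronger inhibitor.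

The step to compound 4 `O=C(O)c1ccc(CN2C(=O)S/C(=C\c3ccco3)C2=O)cc1` alters the group on the double-bonded chain carbon bound to a double-bonded ring carbon: furan-2-yl in place of pyridin-2-yl on a double-bonded chain carbon bound to a double-bonded ring carbon.

For the measured compounds named here, one measured step bears on this position: a 1.1-fold lower number from compound 2 to compound 3 (0.03 log units; within the scatter). That exchange put a different aromatic ring in the place of pyridin-2-yl and left the number within the scatter. Going by the values given here, no step to a five-membered aromatic ring has been measured here, so the only guide is that one exchange of the ring at this place produced no measurable shift. The expected step is therefore a 1.2-fold lower number from compound 2 to compound 4 (0.08 log units; within the scatter), that is, none beyond the scatter. Compound 4 is estimated at 65000 nM, with a range from 30000 nM to 140000 nM.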

Compound 4, half-maximal inhibitory concentration: 94000 nM
Beside the measured number, compound 4's estimate is 1.4-fold (0.16 log units) below it; measured number inside the range.
By their numbers in this assay, from the lowest: compound 1; then compounds 3, 2 and 4 (each within the scatter of the next).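

In this assay, a five-membered aromatic ring at this place, on a double-bonded chain carbon bound to a double-bonded ring carbon, gives a 1.2-fold higher number from compound 2 to compound 4 (0.08 log units; within the scatter) and a 1.3-fold higher number from compound 3 to compound 4 (0.12 log units; within the scatter), so both steps to furan-2-yl stay within the scatter. Compound 2, compound 3 and compound 4 therefore show no readable order, and the exchange of a six-membered for a five-membered aromatic ring, with oxygen taking the place of nitrogen as the hetero atom, has no resolved effect on the number here. No supporting measurement is available to explain this result.

On these data alone, it remains open whether an amine on the aromatic ring at this place, or a saturated ring such as cyclohexyl in place of the aromatic ring, would move the number away from this cluster and toward that of compound 1, 32000 nM. The compounds shown also leave open how the number responds to a change elsewhere on the shared core, such as an amide in place of the carboxylic acid.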